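The source may hold more compounds than are shown below. What is called first, only, known or untested is meant among the compounds shown, and "the series" means these compounds.

Measured in an ADME assay on a cell-free system (plasma, Homo sapiens); a lower number here means a smaller unbound share, a higher number a larger unbound share of the compound:

Compound 1 `COCCN(C)S(=O)(=O)c1ccc(C)c(C#Cc2cc(Cl)ccc2OCC(=O)O)c1`: 0.006
Compound 2 `COCCNS(=O)(=O)c1ccc(C)c(C#Cc2cc(Cl)ccc2OCC(=O)O)c1`: "not determined" (no result reported)

Among the compounds with values here, only one of the two compounds has a number. Compound 1 gives 0.006, while compound 2 stands at "not determined" (no result reported). Compound 2 therefore cannot be placed on the scale, and nothing can be said about how it compares with compound 1.

Compound 3 `Cc1ccc(S(=O)(=O)NC(C)C)cc1C#Cc1cc(Cl)ccc1OCC(=O)O` is the next to be read in this assay. It is reached by a single change at the sulfonamide: isopropyl in place of 2-methoxyethyl on a sulfonamide nitrogen. Put plainly, isopropyl takes the place of 2-methoxyethyl on a sulfonamide nitrogen, and the rest of the structure stays the same.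

Within the data shown here, no measured pair in this small set shows what such a change does, so the size of the step has to be judged without a precedent. A small move towards a lower unbound share is expected, though probably none beyond the usual scatter. Among the measured compounds shown here, the only numerical anchor is compound 1 at 0.006, and the expectation stays close to it.

For compound 3 the estimated value is 0.005, with an expected range from 0.002 to 0.012.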

Compound 3, unbound fraction: 0.004
Beside the measured number, compound 3's estimate is 1.3-fold (0.10 log units) above it; the measured number falls inside the stated range.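

In this assay, within the data shown here, the first readable step at this position is a 1.5-fold lower number from compound 1 to compound 3 (0.18 log units; within the scatter). Replacing (2-methoxyethyl)(methyl)amino with isopropylamino on the sulfonyl sulfur therefore gives two values that cannot be told apart, so this pair shows no sign that the unbound share depends on which of these two groups is present. No measured evidence bears on why the two values lie so close.

The step from compound 2 to compound 3 cannot be read, as compound 2 has no number, so the exchange of 2-methoxyethyl for isopropyl on a sulfonamide nitrogen has not been seen apart from the difference between the (2-methoxyethyl)(methyl)amino and isopropylamino groups in the readable pair. From the compounds shown here alone, it remains open whether a longer chain, a cyclopropyl group, a piperidine ring or a chain bearing an amine on the sulfonamide nitrogen would move the number beyond the scatter, and whether any change elsewhere in the shared core would do so.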